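From phenyl to 3-chlorophenyl in compound 1

A few compounds are considered here, and "the series" means these few. Any claim that something is new, unique, unknown or untested is made for them only; others in the source may bear on it.

For the measured compounds named here, in a functional assay on A549 cells (Homo sapiens) for antiproliferative activity, read by MTT assay, with a stated time of 48 h (on this read-out higher numbers stand for weaker inhibition of growth and lower numbers for stronger inhibition of growth), compound 1 `COC(=O)N1N=C(c2ccccc2)CC1c1cc(OC)c(OC)c(OC)c1` gives 2880 nM, the lowest number measured so far. Compound 2 `CCOC(=O)N1N=C(c2ccccc2)CC1c1cc(OC)c(OC)c(OC)c1` gives 6680 nM. Compound 3 `COc1cc(C2CC(c3ccccc3)=NN2C(=O)OCc2ccccc2)cc(OC)c1OC` gives > 10000 nM, which is a limit of the assay and not a number.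

The measured steps all change the same chain of the molecule. Extending it gives a 2.3-fold higher number from compound 1 to compound 2 (0.37 log units; beyond the scatter), and the larger replacement gives an at least 3.4-fold higher number from compound 1 to compound 3 (0.54 log units; beyond the scatter).

Compound 4 `COC(=O)N1N=C(c2cccc(Cl)c2)CC1c1cc(OC)c(OC)c(OC)c1` keeps the chain of compound 1 and changes a different place: chloro in place of hydrogen on an aromatic carbon. This puts chloro in place of hydrogen on an aromatic carbon, meta to a large group. Going by the values given here, no measured compound carries a change at that place, so the steps above bear on it only loosely. They show how far the number moved for a change elsewhere, but they give no direction for this one. No clear shift is therefore expected, and the uncertainty stays wide.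

The expected size of the change is a 1.2-fold lower number from compound 1 to compound 4 (0.06 log units; within the scatter). For compound 4 the estimate is 2500 nM, with an expected range from 800 nM to 7500 nM.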

Compound 4, concentration for 50% growth inhibition: 340 nM
Compound 4: middle estimate off by 7.4-fold (0.87 log units), on the high side, and the stated range ends above it.
By their numbers in this assay, from the lowest: compound 4; then compound 1; then compound 2. At a limit, above all of these: compound 3.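

Swapping phenyl for 3-chlorophenyl shows that the aromatic carbon meta to a large group is a place where a single chlorine atom can strengthen growth inhibition: in this assay the change gives an 8.5-fold lower number from compound 1 to compound 4 (0.93 log units; beyond the scatter). The earlier compounds changed only the chain, and each of those changes moved the number upward, so this is the first change shown that moves it downward, at a place those compounds left untouched. Nothing measured here explains why chloro has this effect.

Whether the gain belongs to chloro itself stays open, since no other group at this carbon, such as fluoro, methoxy or an amine, appears among the compounds shown. Also open, going by these compounds, are how chloro behaves on the other carbons of that ring and whether it would lower the number for compound 2 as well.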